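A few compounds are considered here, and "the series" means these few. Any claim that something is new, unique, unknown or untested is made for them only; others in the source may bear on it.

Compounds measured so far in an assay on LM cells with Alpha-1B adrenergic receptor (Homo sapiens) as the target; on this read-out lower numbers stand for stronger inhibition and higher numbers for weaker inhibition:

compound 1, `N#Cc1ccccc1C1CCN(CCCNC(=O)C2=CNC(=O)N[C@@H]2c2ccc(F)c(F)c2)CC1`: 290 nM
compound 2, `O=C1NC=C(C(=O)NCCCN2CCC(c3ccc(F)cc3)CC2)[C@@H](c2ccc(F)c(F)c2)N1`: 24 nM

For the measured compounds named here, compound 2 gives the lowest of the two numbers in this assay; the nearest is compound 1, and the one measured step, a 12-fold lower number from compound 1 to compound 2 (1.08 log units; beyond the scatter), separates them. That step exchanges the aryl group on the saturated ring carbon and says nothing about substitution on the shared core of compound 2.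

Compound 3, `COCC1=C(C(=O)NCCCN2CCC(c3ccc(F)cc3)CC2)[C@@H](c2ccc(F)c(F)c2)NC(=O)N1`, carries the change (methoxymethyl in place of hydrogen on a double-bonded ring carbon). Going by the values given here, no measured step touches a double-bonded ring carbon of the core, so the measured data give no direction for it. Among the compounds with values here, the one large step seen concerns a distant part of the molecule and does not bear on this position. As far as these compounds go, the expectation is therefore a step of no clear size beyond the scatter, with the uncertainty widened because the position is untested: the estimate is a 1.5-fold higher number from compound 2 to compound 3 (0.16 log units; within the scatter). For compound 3 the estimated value in this assay is 35 nM, within a range from 10 nM to 120 nM.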

Compound 3, inhibition constant: 41 nM
For compound 3 the middle estimate is 1.2-fold (0.07 log units) below the measured one; low and high end bracket the measured number.
By their numbers in this assay, from the lowest: compounds 2 and 3 (each within the scatter of the next); then compound 1.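

In this assay, methoxymethyl in place of hydrogen on the double-bonded ring carbon gives a 1.7-fold higher number from compound 2 to compound 3 (0.23 log units; within the scatter), so this position, next to the ring nitrogen, accepts the added group with no change that can be separated from the scatter of repeated measurements. For the compounds shown here, this is the only measured information on substitution at this position of the shared core, and it differs in kind from a 12-fold lower number from compound 1 to compound 2 (1.08 log units; beyond the scatter), which lies beyond the scatter and comes from a change at the aryl group on the saturated ring carbon. No supporting data bear on why methoxymethyl and hydrogen give values within the scatter of each other.

As far as these compounds go, a single substituent defines only one point at this position, so the outcome with a plain methyl, a longer ether chain such as ethoxyethyl, an aminomethyl group or a carboxylic acid remains open. Also open, from the compounds shown here alone, is whether methoxymethyl would give a similar step alongside the 2-cyanophenyl group of compound 1, since the present step was read only alongside the 4-fluorophenyl group.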